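Swapping a Propyl Chain for a Difluorophenyl Ring

The source may report more compounds than this note shows. Statements on the series, on what has been measured and on what is new or still open speak of the compounds shown alone.

Measured so far:
Compound 1, `C=CS(=O)(=O)N1CCN(c2ncnc3sc(-c4cn(C)nc4C(F)(F)F)cc23)CC1`, gives 15100 nM in a functional assay on MDA-MB-436 cells (Homo sapiens) for antiproliferative activity, read by MTT assay, with a stated time of 48 h; on this read-out lower numbers stand for stronger inhibition and higher numbers for weaker inhibition.
Compound 2, `C=CS(=O)(=O)N1CCN(c2ncnc3sc(-c4c(C)noc4C)cc23)CC1`, gives 34600 nM in this assay.
Compound 3, `CCCNC(=O)N1CCN(c2ncnc3sc(-c4ccc(N5CCN(C)CC5)cc4)cc23)CC1`, gives 12400 nM in this assay.

Compound 3 has the lowest number of the three, but compound 1 lies within the usual scatter of it, so the two cannot be ranked; only compound 2 stands clearly higher, beyond the scatter.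

Compound 4, `CN1CCN(c2ccc(-c3cc4c(N5CCN(C(=O)Nc6ccc(F)cc6F)CC5)ncnc4s3)cc2)CC1`, is compound 3 with one change: 2,4-difluorophenyl in place of propyl on an amide-type nitrogen. Among the compounds with values here, the only measured step, a 2.3-fold higher number from compound 1 to compound 2 (0.36 log units; beyond the scatter), concerns a different part of the molecule, the aromatic group attached to the shared core, and was modest in size. Within the data shown here, no measured step touches the amide-type nitrogen, so there is no direct precedent for exchanging propyl for 2,4-difluorophenyl there.

Given that the one known change elsewhere in this series moved the number only modestly, compound 4 is expected to land near compound 3, with a wide range to reflect the missing precedent. The expected step is a 1.4-fold lower number from compound 3 to compound 4 (0.14 log units; within the scatter). Compound 4 is estimated at 9000 nM in this assay, between 2500 nM and 32000 nM.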

Compound 4, half-maximal inhibitory concentration: 20200 nM
Beside the measured number, compound 4's estimate is 2.2-fold (0.35 log units) below it; low and high end bracket the measured number.
By their numbers in this assay, from the lowest: compounds 3, 1, 4 and 2 (each within the scatter of the next, the first and the last beyond it).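

Within the data shown here, this is the first measured change at the amide-type nitrogen, since the earlier step concerned only the aromatic group on the shared core. Replacing propyl, a chain of 3 heavy atoms with no ring, with 2,4-difluorophenyl, which has 8 heavy atoms and a six-membered aromatic ring, gives a 1.6-fold higher number from compound 3 to compound 4 (0.21 log units; within the scatter) in this assay, so this large change in the group leaves the two compounds indistinguishable on this read-out. No measurement is available here that would explain this result.

The compounds shown leave open whether any group at this nitrogen can shift the number beyond the scatter, for example plain phenyl without fluorine, a longer chain such as hexyl, or a chain ending in an amine or a carboxylic acid. They also leave open whether the fluorine atoms matter at all, and whether propyl and 2,4-difluorophenyl would still match if the aromatic group on the shared core were different.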